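This account rests on a few compounds, and the source may have more. Where it says the series, first, only, none or still open, it means among the compounds named here.

Compound 1 `CC(=O)N[C@H]1[C@@H](OC[C@@H](O)[C@@H](O)[C@H](O)[C@@H](O)CNc2cccc(NC(=O)CCCCC3CCSS3)c2)O[C@H](CO)[C@H](O)[C@@H]1O[C@@H]1O[C@H](C(=O)O)[C@@H](O)[C@H](O)[C@H]1OS(=O)(=O)O`: 62 nM
Compound 2 `CC(=O)N[C@H]1[C@@H](OC[C@@H](O)[C@@H](O)[C@H](O)[C@@H](O)CNc2cccc(NC(=O)CCCCC3CCSS3)c2)O[C@H](CO)[C@H](O)[C@@H]1O[C@@H]1O[C@H](C(=O)O)[C@@H](O)[C@H](OS(=O)(=O)O)[C@H]1O`: 25 nM
Compound 3 `CC(=O)N[C@H]1[C@@H](OC[C@@H](O)[C@@H](O)[C@H](O)[C@@H](O)CNc2cccc(NC(=O)CCCCC3CCSS3)c2)O[C@H](COS(=O)(=O)O)[C@H](O)[C@@H]1O[C@@H]1O[C@H](C(=O)O)[C@@H](O)[C@H](O)[C@H]1OS(=O)(=O)O`: 23 nM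

The three measured compounds were tested in an assay on isolated protein for binding affinity to fibroblast growth factor 2 (Homo sapiens), read by surface plasmon resonance; a lower number here means tighter binding, a higher number weaker binding. Compound 1 gives 62 nM. Compound 3 is built from compound 1 by a single change, (sulfo in place of hydrogen on an oxygen on a saturated carbon), and in this assay compound 3 gives 23 nM. That change made a step of a 2.7-fold lower number from compound 1 to compound 3 (0.43 log units; beyond the scatter).

Compound 2 has the same atoms as compound 1 joined differently; the difference between the two cores is not broken down here. In this assay compound 2 gives 25 nM. The numbers for compound 2 and compound 3 lie within the usual scatter of each other, so nothing separates them, while compound 2 and compound 1 are separated by more than the scatter.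

Compound 4 `CC(=O)N[C@H]1[C@@H](OC[C@@H](O)[C@@H](O)[C@H](O)[C@@H](O)CNc2cccc(NC(=O)CCCCC3CCSS3)c2)O[C@H](COS(=O)(=O)O)[C@H](O)[C@@H]1O[C@@H]1O[C@H](C(=O)O)[C@@H](O)[C@H](OS(=O)(=O)O)[C@H]1O` has not yet been measured. It is made from compound 2 by sulfo in place of hydrogen on an oxygen on a saturated carbon, the same change that leads from compound 1 to compound 3, made at the same kind of place: on an oxygen on a saturated carbon whose other neighbour is a saturated chain carbon. Among the measured compounds shown here, with only one earlier example of this change, the expectation rests on that single measured step, a 2.7-fold lower number from compound 1 to compound 3 (0.43 log units; beyond the scatter). On that basis the step from compound 2 to compound 4 is expected to be a 2.1-fold lower number from compound 2 to compound 4 (0.32 log units; beyond the scatter), though a smaller step would not be surprising given that the first one was itself modest. Compound 4 is therefore estimated to give about 12 nM in this assay, most likely somewhere between 5 nM and 30 nM.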

Compound 4, dissociation constant: 147 nM
For compound 4 the middle estimate is 12-fold (1.09 log units) below the measured one; the whole stated range lies below it.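

In this assay, putting a sulfo group on the oxygen of the hydroxymethyl group, which turns it into (sulfooxy)methyl, gives a step of a 5.9-fold higher number from compound 2 to compound 4 (0.77 log units; beyond the scatter), so binding becomes weaker on this core. The same change made binding tighter on the core of compound 1, so in this series its effect cannot simply be carried from one core to another, and even the direction of the step depends on the core it is made on: the same change on two cores in this assay, a 2.7-fold lower number (0.43 log units; beyond the scatter) from compound 1 to compound 3 and a 5.9-fold higher number (0.77 log units; beyond the scatter) from compound 2 to compound 4, 16-fold (1.20 log units) apart, beyond the scatter of two such steps. Among the compounds shown here, this is only one pair of steps on two cores, so it shows that the outcome depends on the core but not why, nor which feature of the two cores is responsible, and it gives no rule for predicting the step on any further core.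

The compounds shown leave open whether the weaker binding of compound 4 is specific to the sulfo group, since a phosphate group or a methyl ether on the same oxygen would be needed to test this on both cores. They also leave open how a sulfo group placed on one of the other hydroxy groups would behave on each core.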